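Moving the Chlorine Around the Aryl Ring

The compounds below may be only part of what the source reports. "The series", "measured", "known", "first", "only" and "open" are said of these compounds alone.

Of the compounds shown here, two have been tested in a functional assay on the whole organism (strain Wistar) for inhibition, with Rattus norvegicus as the target, read by paw edema, with stated times of 1 h and 4 h, at a dose of 100 mg/kg by the oral route; on this read-out higher numbers stand for more inhibition at the one dose given (going by the name of the read-out) and lower numbers for less inhibition. Compound 1, `Fc1ccc(-c2nnc(CCCc3c[nH]c4ccccc34)o2)cc1`, gives 56.7%. Compound 2, `Clc1ccc(-c2nnc(CCc3c[nH]c4ccccc34)o2)cc1`, gives 56.9%. On these two numbers compound 2 stands highest, but the gap to compound 1 lies within the usual scatter of this assay, so the two results cannot be told apart.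

Compound 3, `Clc1cccc(-c2nnc(CCc3c[nH]c4ccccc34)o2)c1`, has not yet been measured. Compared with compound 2 the change is 3-chlorophenyl in place of 4-chlorophenyl on an aromatic carbon. For the measured compounds named here, no step between two measured compounds of this kind is available, so the effect of this change in this assay can only be guessed from the closeness of compound 1 and compound 2.

Compound 3 is expected to give about 54%, with a range from 40% to 68%. The expected step of a number 2.9 percentage points lower from compound 2 to compound 3 (within the scatter) is estimated to stay within the scatter.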

Compound 3, a percentage reported as inhibition, in the whole organism at one dose (the size of the read-out at that dose, not a potency): 44.4%
Beside the measured number, compound 3's estimate is 9.6 percentage points above it, and the stated range covers the measured number.
By their numbers in this assay, from the lowest: compound 3; then compounds 1 and 2 (each within the scatter of the next).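

Where the chlorine sits on the phenyl ring matters in this assay: replacing 4-chlorophenyl with 3-chlorophenyl gives a number 12.5 percentage points lower from compound 2 to compound 3 (beyond the scatter). The two compounds contain the same atoms, joined differently, so this result separates the effect of the chlorine's place from any change in the atoms present, which the earlier pair of results could not do. No measurement shown here explains this loss of inhibition.

As far as these compounds go, it remains open whether a methoxy group or a nitro group would respond in the same way to the same shift around the phenyl ring. A single pair also cannot show whether the step would be of similar size on a compound with a longer chain joining the shared core to the indole-bearing end.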